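A Single Fluorine Added to Compound 2

This account rests on a few compounds, and the source may have more. Where it says the series, first, only, none or still open, it means among the compounds named here.

Compound 1, `CC(C)Oc1ccc(C(O)(c2ccc(C(F)(F)F)cc2)c2cccnc2)cc1`: 1.6 ug/mL
Compound 2, `N#Cc1ccc(C(O)(c2ccc(C(F)(F)F)cc2)c2cccnc2)cc1`: 6.3 ug/mL

Of the compounds shown here, two have been measured in a physicochemical assay for solubility, read by nephelometry, measured as kinetic solubility, at pH 6.5; on this read-out higher numbers stand for higher solubility and lower numbers for lower solubility. Compound 1 gives 1.6 ug/mL, and compound 2 gives 6.3 ug/mL, the higher of the two numbers. Among the measured compounds shown here, the only step between them, a 3.9-fold higher number from compound 1 to compound 2 (0.60 log units; beyond the scatter), comes from cyano in place of isopropoxy on an aromatic carbon.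

Compound 3, `N#Cc1ccc(C(O)(c2ccc(C(F)(F)F)cc2)c2cccnc2)c(F)c1`, keeps the whole of compound 2 and differs from it in one place: fluoro in place of hydrogen on an aromatic carbon. For the measured compounds named here, no measured step involves a fluoro, so the one step available, from an isopropoxy to a cyano group, does not bear directly on this change. With nothing in the data pointing one way, a step within the usual scatter is expected, a 1.3-fold lower number from compound 2 to compound 3 (0.10 log units; within the scatter), leaning slightly downward. Compound 3 is therefore estimated at 5 ug/mL, with a range from 2 ug/mL to 12 ug/mL.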

Compound 3, solubility: 6.3 ug/mL
Compound 3: the middle estimate sits 1.3-fold (0.10 log units) below what was measured; low and high end bracket the measured number.
By their numbers in this assay, from the lowest: compound 1; then compounds 2 and 3 (each within the scatter of the next).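

In this assay, putting fluoro in place of hydrogen on this aromatic carbon, ortho to a large group and meta to a cyano group, gives no change at the digits printed from compound 2 to compound 3 (within the scatter). This position therefore accepts one added fluorine with no shift beyond the scatter, whereas the earlier swap of isopropoxy for cyano, a 3.9-fold higher number from compound 1 to compound 2 (0.60 log units; beyond the scatter), did move the number beyond it. Nothing available explains why the number holds steady here.

A single fluoro at a single position leaves open whether a chloro, a methoxy or an amine on this same carbon would also keep the number in place. As far as these compounds go, it is equally open whether a fluoro on another aromatic carbon, or on the isopropoxy compound 1, would give the same result.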